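Swapping the amide aryl group in a dopamine receptor agonist

The source may hold more compounds than are shown below. What is called first, only, known or untested is meant among the compounds shown, and "the series" means these compounds.

Measured compounds:
compound 1, `O=C(CN1CCN(c2ccccn2)CC1)Nc1cccnc1`: 19%
compound 2, `Cc1cccc(NC(=O)CCN2CCC(c3ccccn3)CC2)c1`: "not active" (no number reported)
compound 3, `Cc1ccc(C2CCN(CC(=O)Nc3cccc(C)c3)CC2)cc1`: "not active" (no number reported)

In an assay on cells for agonist activity at D(4) dopamine receptor (Homo sapiens), read by luminescence and beta-arrestin recruitment, with a stated time of 90 min (a lower number here means a smaller maximal response, a higher number a larger maximal response), compound 1 gives 19%. Among the compounds with values here, this is the only number in the set. Compound 2 is reported in this assay as "not active" (no number reported), and compound 3 likewise as "not active" (no number reported). Within the data shown here, both of these carry the 3-methylphenyl amide but differ from compound 1 in their cores, so no single step between measured compounds can be counted.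

Compound 4, `Cc1cccc(NC(=O)CN2CCN(c3ccccn3)CC2)c1`, keeps the core of compound 1 and differs from it in one place: 3-methylphenyl in place of pyridin-3-yl on an amide-type nitrogen. Among the measured compounds shown here, no measured pair shows this change on its own. Because compound 2 is recorded as "not active" (no number reported) and compound 3 is recorded as "not active" (no number reported), these being the two entries with this same aryl amide, a step downward from compound 1 is expected, in size roughly a number 9 percentage points lower from compound 1 to compound 4 (within the scatter), possibly to the point where only an inactive result is reported. Compound 4 is therefore estimated at 10%, within 0% to 22%.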

Compound 4, largest response reached (Emax), in percent of the reference or control that the assay uses: 30.7%
Compound 4: middle estimate off by 20.7 percentage points, on the low side; the measured number lies above the stated range.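

At the amide-type nitrogen on the core of compound 1, 3-methylphenyl in place of pyridin-3-yl gives, in this assay, a number 11.7 percentage points higher from compound 1 to compound 4 (beyond the scatter). The two earlier entries with this aryl amide, both reported as not active, have other cores, and compound 4 shows that the same aryl group can carry a measurable maximal response when the core of compound 1 is kept. Nothing shown explains why the response moves in this direction.

The step combines two changes, the swap of the pyridine ring for a benzene ring and the added methyl, and plain phenyl on the amide nitrogen would be needed to separate them. Going by these compounds, how an amine or a carboxylic acid on that ring would behave also stays open, as does a longer chain linking the amide carbonyl to the core.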